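Hydroxypiperidine Replaces Methylpiperazine at the Chain End

The source may report more compounds than this note shows. Statements on the series, on what has been measured and on what is new or still open speak of the compounds shown alone.

Compound 1 `O=C1c2c[n+]([O-])c3ccccc3c2C(=O)c2c1c1ccccc1n2Cc1cn(C[C@@H](O)CO)nn1`: > 500 nM, a limit of the assay
Compound 2 `O=C1c2c[n+]([O-])c3ccccc3c2C(=O)c2c1c1ccccc1n2CCCCN1CCCCC1`: 230 nM
Compound 3 `CN1CCN(CCCn2c3c(c4ccccc42)C(=O)c2c[n+]([O-])c4ccccc4c2C3=O)CC1`: 560 nM

In a functional assay on SH-SY5Y cells (Homo sapiens) for cytotoxicity, read by MTT assay, with a stated time of 72 h (a higher number here means a weaker inhibitor, a lower number a stronger inhibitor), compound 3 stands highest of the two numbers; its nearest neighbour is compound 2, with a 2.4-fold higher number from compound 2 to compound 3 (0.39 log units; beyond the scatter). The value of compound 1 is a limit (the limit of > 500 nM in this assay, at which 1 of the 3 values shown sits), so a step that the limit leaves unreadable from compound 1 to compound 3 cannot be sized, while an at least 2.1-fold lower number from compound 1 to compound 2 (0.33 log units; beyond the scatter) is at least modest. Compound 4 `O=C1c2c[n+]([O-])c3ccccc3c2C(=O)c2c1c1ccccc1n2CCCN1CCC(O)CC1` differs from compound 3 by 4-hydroxypiperidin-1-yl in place of 4-methylpiperazin-1-yl on a saturated chain carbon, three bonds along the chain from an aromatic nitrogen. The step that bears on it most is a 2.4-fold higher number from compound 2 to compound 3 (0.39 log units; beyond the scatter), a modest change in the same region of the chain. Compound 4 is therefore expected to give a modestly lower number, a 1.8-fold lower number from compound 3 to compound 4 (0.24 log units; within the scatter), with an estimate of 320 nM ranging from 150 nM to 700 nM.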

Compound 4, half-maximal inhibitory concentration: 130 nM
Compound 4: middle estimate off by 2.5-fold (0.39 log units), on the high side, and the stated range ends above it.
By their numbers in this assay, from the lowest: compounds 4 and 2 (each within the scatter of the next); then compound 3.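

In this assay, the swap at the chain end gives a 4.3-fold lower number from compound 3 to compound 4 (0.63 log units; beyond the scatter), so the ring on this chain can move the number beyond the scatter even with no net charge on either group. The change also gives a 1.8-fold lower number from compound 2 to compound 4 (0.25 log units; within the scatter), which places compound 4 level with compound 2 rather than with compound 3. Replacing 1-(2,3-dihydroxypropyl)-1H-1,2,3-triazol-4-yl gives an at least 3.8-fold lower number from compound 1 to compound 4 (0.58 log units; beyond the scatter), a step that rests on a limit: the limit of > 500 nM in this assay, at which 1 of the 4 values shown sits.

Whether the hydroxyl group or the loss of the second ring nitrogen accounts for the step remains open. A morpholine or a 4-methoxypiperidine at the same chain end could separate the two.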